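Trimming the Propoxy Chain by One Carbon

This account rests on a few compounds, and the source may have more. Where it says the series, first, only, none or still open, it means among the compounds named here.

Three compounds have numbers in a functional assay on KB cells (Homo sapiens) for cytotoxicity (on this read-out higher numbers stand for weaker inhibition and lower numbers for stronger inhibition), so far. Compound 1 (`CCCOC1=CC(=O)c2ccccc2C1=O`) gives 49400 nM and compound 2 (`COc1ccc2c(c1)C(=O)C=CC2=O`) gives 33900 nM which puts these two within the scatter of each other. For the measured compounds named here, compound 3 (`O=C1C=CC(=O)c2c(Oc3ccco3)cccc21`) gives 13400 nM and that number is lower than the one for compound 1 by more than the scatter. Compound 1 therefore stands at the high-number, weaker end of this small set, level with compound 2.

Compound 4 (`CCOC1=CC(=O)c2ccccc2C1=O`) has not been measured. It differs from compound 1 by one small edit, hydrogen in place of methyl on a saturated chain carbon, two bonds along the chain from an oxygen on an unsaturated carbon which turns propoxy into ethoxy. Going by the values given here, no measured pair shows this change, so its size cannot be read directly from the data. The estimate amounts to a 1.2-fold lower number from compound 1 to compound 4 (0.07 log units; within the scatter) and this expected step stays within the scatter, with no firm direction. For compound 4 the expected value is 42000 nM with an estimated range from 19000 nM to 90000 nM as the likely span.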

Compound 4, half-maximal inhibitory concentration: 16900 nM
For compound 4 the middle estimate is 2.5-fold (0.40 log units) above the measured one; the measured number lies below the stated range.
By their numbers in this assay, from the lowest: compounds 3, 4, 2 and 1 (each within the scatter of the next, the first and the last beyond it).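

Shortening propoxy to ethoxy on the shared core is not a silent edit: in this assay the step is a 2.9-fold lower number from compound 1 to compound 4 (0.47 log units; beyond the scatter), which here means stronger inhibition. For the compounds shown here, this is the first pair in the set that differs in one place, and it shows that the read-out responds at this chain end, even though only a methyl leaves, a hydrogen enters, and no ring, hydrogen-bond donor, hydrogen-bond acceptor or charge is involved. Nothing on hand accounts for the size or direction of this step.

On these data alone, a single pair gives one step and not a trend, so the direction of change for a longer butoxy chain at this place remains open. As far as these compounds go, it is also open how an amine at the end of the chain would compare with the ethoxy of compound 4.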